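Swapping Phenyl for Propyl on the Thione Core

The source may report more compounds than this note shows. Statements on the series, on what has been measured and on what is new or still open speak of the compounds shown alone.

Measured compounds:
compound 1, `O=C(CCc1ccccc1)n1c(=S)[nH]c2ccccc21`, 100000 nM
compound 2, `CCCCCC(=O)n1c(=S)oc2ccccc21`, 130000 nM
compound 3, `O=C(CCCc1ccccc1)n1c(=S)oc2ccccc21`, 100000 nM

In a physicochemical assay for solubility (a higher number here means a more soluble compound, a lower number a less soluble compound), compound 1 gives 100000 nM, the same number at the digits shown as compound 3, and the number of compound 2 lies within the scatter of both. The three values therefore sit together, with no difference that can be called real.

Compound 4, `CCCCCC(=O)n1c(=S)[nH]c2ccccc21`, keeps the shared core of compound 1 and carries one change: propyl in place of phenyl on a saturated chain carbon, two bonds along the chain from a carbonyl carbon. Within the data shown here, the only measured step that resembles this swap runs on the other core, between compound 2 and compound 3, where a phenyl replaced an ethyl three bonds along the chain from the carbonyl carbon: a 1.3-fold lower number from compound 2 to compound 3 (0.11 log units; within the scatter). That step stayed within the scatter, so a chain in place of a ring gave no visible shift there.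

On that basis no change beyond the scatter is expected from compound 1 to compound 4: a 1.2-fold higher number from compound 1 to compound 4 (0.08 log units; within the scatter). Compound 4 is estimated at 120000 nM in this assay, between 60000 nM and 250000 nM.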

Compound 4, solubility: 170000 nM
The estimate for compound 4 lay 1.4-fold (0.15 log units) below the measured number; the measured number falls inside the stated range.
By their numbers in this assay, from the lowest: compounds 1, 3, 2 and 4 (each within the scatter of the next).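

On the shared core of compound 1, propyl in place of phenyl on a saturated chain carbon, two bonds along the chain from a carbonyl carbon, gives a 1.7-fold higher number from compound 1 to compound 4 (0.23 log units; within the scatter) in this assay. Among these compounds, at this place on this core, then, an open chain can stand where the aromatic ring stood with no difference that can be called real, something the earlier compounds showed only on the core of compound 2 and compound 3, three bonds along the chain from a carbonyl carbon. Nothing measured here offers an explanation for these numbers.

From the compounds shown here alone, whether an amine or a carboxylic acid at this place would move the number beyond the scatter remains open. So does the outcome for a longer chain on the core of compound 1.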